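The Same Exchange Tried on a Second Core

The source may report more compounds than this note shows. Statements on the series, on what has been measured and on what is new or still open speak of the compounds shown alone.

Compound 1 `CS/C(=N\C(=O)c1csc([N+](=O)[O-])c1)NC(=O)c1csc([N+](=O)[O-])c1` and compound 3 `CS/C(=N\C(=O)c1cnc2ccccc2c1)NC(=O)c1cnc2ccccc2c1` both carry a methylsulfanyl group; the difference between their two cores is not broken down here. In a functional assay on MCF7 cells (Homo sapiens) for cytotoxicity, read by MTT assay, with a stated time of 72 h (a lower number here means that less compound is tolerated, a higher number that more compound is tolerated), compound 1 reaches only the limit of the measurement, > 100000 nM. Compound 3 likewise gives only a limit in this assay, > 100000 nM. Compound 2 `O=C(/N=C(/NC(=O)c1csc([N+](=O)[O-])c1)[Se]Cc1ccccc1)c1csc([N+](=O)[O-])c1` differs from compound 1 by a group of 8 heavy atoms (7 carbon, 1 selenium; one six-membered aromatic ring of carbon only) in place of a group of 2 heavy atoms (1 carbon, 1 sulfur; no ring), on a carbon with a double bond to nitrogen. In this assay compound 2 gives 83800 nM, so that an at least 1.1-fold lower number from compound 1 to compound 2 (0.07 log units; that floor lies within the scatter). That this step can be stated only as a minimum is because compound 1 sits at the limit of > 100000 nM in this assay, at which 2 of the 3 values shown sit. Compound 4 `O=C(/N=C(/NC(=O)c1cnc2ccccc2c1)[Se]Cc1ccccc1)c1cnc2ccccc2c1` carries the same change on the core of compound 3, namely (a group of 8 heavy atoms (7 carbon, 1 selenium; one six-membered aromatic ring of carbon only) in place of a group of 2 heavy atoms (1 carbon, 1 sulfur; no ring), on a carbon with a double bond to nitrogen). Because an at least 1.1-fold lower number from compound 1 to compound 2 (0.07 log units; that floor lies within the scatter) stays within the scatter, a step of similar size is expected here, an at least 1.1-fold lower number from compound 3 to compound 4 (0.04 log units; that floor lies within the scatter). Compound 4 is therefore estimated at 90000 nM in this assay, expected to fall between 40000 nM and 200000 nM.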

Compound 4, concentration lethal to 50% of the cells: > 100000 nM
Compound 4 gave a limit, no number; the forecaster's own chance of this, stated with the estimate: 45%; at least 1.1-fold (0.04 log units) between middle value and limit.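

Compound 3 and compound 4 both end at a limit, so no step can be read between them: (the limit of > 100000 nM in this assay, at which 3 of the 4 values shown sit). Going by these compounds, whether the group of 8 heavy atoms in place of methylsulfanyl shifts the number at all on the core of compound 3 stays open.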